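The compounds below may be only part of what the source reports. "The series", "measured", "known", "first", "only" and "open" are said of these compounds alone.

Measured so far:
compound 1, `CNc1nc(O)c(Br)c(-c2ccccc2)n1`, which in a functional assay on the whole organism for inhibition, with Rattus norvegicus as the target, at a dose of 50 mg/kg by the oral route (on this read-out higher numbers stand for a stronger effect at the one dose given and lower numbers for a weaker effect), gave 78%;
compound 2, `Cn1c(N)nc(-c2ccccc2)c(I)c1=O`, which gave 30%;
compound 3, `Cn1c(-c2ccccc2)c(I)c(=O)[nH]c1=O`, which gave 44%.

Among these three numbers compound 1 stands highest. Its nearest neighbour is compound 3, whose number is lower by a margin beyond the scatter; compound 2 lies further off, again beyond the scatter. Among the measured compounds shown here, no pair of the measured compounds differs in one place only, so there is no single measured step to lean on.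

Compound 4, `Oc1nc(O)c(Br)c(-c2ccccc2)n1`, has not yet been measured. It differs from compound 1 in one place: hydroxy in place of methylamino on an aromatic carbon. The methylamino group leaves and a hydroxy group enters on an aromatic carbon of a six-membered aromatic ring with 2 nitrogen, between two ring nitrogen atoms, para to a bromo group.

What can be said rests on the three numbers. Compound 4 keeps the bromo and the phenyl of compound 1 but not the methylamino; the two measured compounds that carry no methylamino, compound 2 and compound 3, gave lower numbers than compound 1, though neither is a one-place neighbour of compound 4. The step from compound 1 to compound 4 is therefore expected to be downward and beyond the scatter, about a number 23 percentage points lower from compound 1 to compound 4 (beyond the scatter). Compound 4 is estimated to give 55% in this assay, with a range from 30% to 78%.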

Compound 4, a percentage reported as inhibition, in the whole organism at one dose (the size of the read-out at that dose, not a potency): 46%
Beside the measured number, compound 4's estimate is 9 percentage points above it; low and high end bracket the measured number.
By their numbers in this assay, from the lowest: compound 2; then compounds 3 and 4 (each within the scatter of the next); then compound 1.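

In this assay, the exchange of hydroxy for methylamino on the aromatic carbon between two ring nitrogen atoms gives the first single-place step available here, a number 32 percentage points lower from compound 1 to compound 4 (beyond the scatter), a large one that lies beyond the scatter. Among the compounds shown here, with the bromo group, the phenyl and the rest of the core kept, this shows that the read-out responds to the group at this position, which the earlier compounds, none a one-place neighbour of another, could not show. The change swaps a group of two heavy atoms for one of a single heavy atom, while the counts of hydrogen-bond donors and acceptors and the lack of net charge stay the same, and nothing available explains the fall in the number.

The compounds shown leave open whether the fall goes with the loss of the nitrogen or of the methyl, a question that a plain amine, dimethylamino, ethylamino or methoxy at this position would bear on. They also leave open how far a longer chain on the nitrogen would carry the number, and whether iodo in place of the bromo group would alter it on this core.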